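Working notes: from compound 1 to compound 4

The compounds below may be only part of what the source reports. "The series", "measured", "known", "first", "only" and "open" are said of these compounds alone.

In a functional assay on MCF7 cells (Homo sapiens) for antiproliferative activity, read by MTT assay, with a stated time of 48 h (a higher number here means a weaker inhibitor, a lower number a stronger inhibitor), compound 1 (`COc1ccc(/C=C/C(=O)Nc2cc(-c3ccc(Br)cc3)[nH]n2)cc1`) gives 590 nM. Compound 2 (`Cc1ccc(-c2cc(NC(=O)/C=C/c3ccc(C(F)(F)F)cc3)n[nH]2)cc1`) gives 720 nM, and compound 3 (`Cc1ccc(-c2cc(NC(=O)/C=C/c3ccc(F)cc3)n[nH]2)cc1`) gives 950 nM. Compound 1 lies within the scatter of both of the others, so these three values do not separate into a ranking.

The next compound to be measured is compound 4 (`O=C(/C=C/c1ccc(Cl)cc1)Nc1cc(-c2ccc(Br)cc2)[nH]n1`). It keeps the core of compound 1 and differs by one substituent: chloro in place of methoxy on an aromatic carbon. In words, this is chloro in place of methoxy on an aromatic carbon, para to a large group.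

Among the measured compounds shown here, no measured step covers this exchange, and no measured compound carries chloro. The nearest evidence is a 1.3-fold higher number from compound 2 to compound 3 (0.12 log units; within the scatter), which also exchanges one substituent on an aromatic carbon. That step stays within the scatter, but it involves different groups and is only a loose guide. On that limited basis, no change beyond the scatter is expected in this assay, and no direction can be firmly assigned.

The expected step is a 1.2-fold higher number from compound 1 to compound 4 (0.07 log units; within the scatter), an estimate that stays within the scatter. For compound 4 the estimated value is 700 nM, with an expected range from 300 nM to 1600 nM.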

Compound 4, half-maximal inhibitory concentration: 770 nM
For compound 4 the middle estimate is 1.1-fold (0.04 log units) below the measured one, within the range that was stated.
By their numbers in this assay, from the lowest: compounds 1, 2, 4 and 3 (each within the scatter of the next).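

In this assay, the exchange of 4-methoxyphenyl for 4-chlorophenyl on the core of compound 1 can now be read directly as a 1.3-fold higher number from compound 1 to compound 4 (0.12 log units; within the scatter) and stays within the scatter. Among the compounds shown here, in this one pair, methoxy, with 2 heavy atoms and 1 hydrogen-bond acceptor, gives way at this position, para to a large group, to chloro, with 1 heavy atom and 0 hydrogen-bond acceptors, with no change that the assay can resolve; the earlier compounds held no pair with this exchange, and the only earlier step, a 1.3-fold higher number from compound 2 to compound 3 (0.12 log units; within the scatter) for fluoro in place of trifluoromethyl, concerns other groups. No supporting measurement is available that could explain this outcome.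

The compounds shown leave open whether any group at this position moves the number beyond the scatter, for example an amine, a carboxylic acid or a longer chain such as butoxy. For the compounds shown here, they also leave open what bromo contributes on its own, as no pair here isolates the exchange of bromo for methyl with the rest of the structure held fixed.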